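The source may report more compounds than this note shows. Statements on the series, on what has been measured and on what is new or still open speak of the compounds shown alone.

Measured so far in a functional assay on PC-3 cells (Homo sapiens) for antiproliferative activity, read by MTT assay, tested at 5 uM; a higher number here means a stronger effect of the compound at the concentration tested, a lower number a weaker effect:

compound 1, `COc1cc(C(=O)N/N=C/c2ccc(F)c(F)c2)cc(OC)c1OC`: 43.7%
compound 2, `COc1cc(C2=NN(C(C)=O)C(c3ccccc3C(F)(F)F)O2)cc(OC)c1OC`: 15.2%
compound 3, `COc1cc(/C=N/NC(=O)c2cc(OC)c(OC)c(OC)c2)cc(OC)c1OC`: 48.3%

Among these three numbers compound 1 stands second highest. Its nearest neighbour is compound 3, whose number lies within the usual scatter of it, so the two cannot be told apart; compound 2 lies far lower, beyond the scatter.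

Compound 4, `COc1cc(C(=O)N/N=C/c2ccc(F)cc2)cc(OC)c1OC`, has not yet been measured. It differs from compound 1 in one place:

hydrogen in place of fluoro on an aromatic carbon

Within the data shown here, no measured pair shows a change of this kind, so these data give no direct guide to its size. A small step, not beyond the scatter, is expected, with either direction possible. In this assay compound 4 is expected to give about 38%, most likely between 20% and 55%. The expected step is a number 5.7 percentage points lower from compound 1 to compound 4 (within the scatter).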

Compound 4, a percentage reported as inhibition, at one concentration (the size of the read-out at that concentration, not a potency): 82.8%
Estimate against measurement, compound 4: 44.8 percentage points below; measured number above the stated range.
By their numbers in this assay, from the lowest: compound 2; then compounds 1 and 3 (each within the scatter of the next); then compound 4.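

In this assay, replacing one fluoro with hydrogen, which turns 3,4-difluorophenyl into 4-fluorophenyl, gives a number 39.1 percentage points higher from compound 1 to compound 4 (beyond the scatter). This position, on an aromatic carbon ortho to a fluoro group, is therefore far from neutral: a change of a single atom on the ring alters the read-out strongly. Nothing shown here gives a reason for this step.

The compounds shown leave open whether a chlorine or an amine at this position would keep the higher read-out of compound 4. They also leave open what removing the remaining fluoro, to give a plain phenyl ring, would do.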